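This account rests on a few compounds, and the source may have more. Where it says the series, first, only, none or still open, it means among the compounds named here.

The measured compounds, all in a functional assay on CHO cells for agonist activity at Alpha-1A adrenergic receptor (Homo sapiens), read by FLIPR and calcium flux; on this read-out lower numbers stand for an effect already at smaller amounts and higher numbers for an effect only at larger amounts of compound:
Compound 1, `COc1cccc2c1CCC2c1ncc[nH]1`, gives 32 nM.
Compound 2, `CS(=O)(=O)Nc1cccc2c1CCCC2c1ncc[nH]1`, gives 2150 nM; 142 nM; 234 nM (3 entries).
Compound 3, `COc1c(Cl)ccc2c1CCC2c1ncc[nH]1`, gives 451 nM.

Of the two single numbers, compound 1 stands lowest; its nearest neighbour is compound 3, with a 14-fold higher number from compound 1 to compound 3 (1.15 log units; beyond the scatter). Compound 2 has no single number, only (the several entries of compound 2 in this assay, 2150 nM; 142 nM; 234 nM (3 entries)), which spreads over a wide interval and so serves poorly as a reference.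

Compound 4, `c1cc(-c2cn[nH]c2)c2c(c1)C(c1ncc[nH]1)CC2`, is not yet measured. It differs from compound 1 by 1H-pyrazol-4-yl in place of methoxy on an aromatic carbon. Within the data shown here, no measured step bears directly on this change: the one step available keeps the methoxy and adds a chloro, while compound 2 carries a different core and a different group, so its entries offer no comparison. The entering 1H-pyrazol-4-yl brings a five-membered aromatic ring with one hydrogen-bond donor where the methoxy brought no ring and no donor, a change larger in kind than the step to compound 3. Since the only shown alteration to the core of compound 1 moved the number upward, a higher number is expected for compound 4 as well, with wide uncertainty. Compound 4 is therefore estimated at 160 nM, in a range from 30 nM to 900 nM, which would mean a 5.0-fold higher number from compound 1 to compound 4 (0.70 log units; beyond the scatter).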

Compound 4, half-maximal effective concentration: 14 nM
The estimate for compound 4 lay 11-fold (1.06 log units) above the measured number; the measured number lies below the stated range.
By their numbers in this assay, from the lowest: compound 4; then compound 1; then compound 3.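

In this assay, the methoxy on this aromatic carbon, ortho to a fused ring and meta to a fused ring, proves replaceable by the larger 1H-pyrazol-4-yl, with a 2.3-fold lower number from compound 1 to compound 4 (0.36 log units; beyond the scatter). Among these compounds, the earlier compounds showed only one change to the core of compound 1, a chloro in place of hydrogen on an aromatic carbon, which went the other way with a 14-fold higher number from compound 1 to compound 3 (1.15 log units; beyond the scatter); the new step therefore shows that a change to the aromatic ring of compound 1 need not raise the number, and that a low number at this position does not depend on the methoxy, with its lack of a ring and of a hydrogen-bond donor. Nothing measured among the compounds shown gives a cause for this step.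

The 1H-pyrazol-4-yl brings its five-membered aromatic ring and its hydrogen-bond donor together, and the compounds shown do not tell which of the two goes with the lower number. Also open, going by these compounds, is how a phenyl ring, a pyrazole with a methyl group on its ring nitrogen, an amine or a carboxylic acid would behave on this same carbon.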